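The source may hold more compounds than are shown below. What is called first, only, known or untested is meant among the compounds shown, and "the series" means these compounds.

Compound 1 `CCc1nc(Cl)c2n1CCN([C@@H](C(=O)NC)c1ccccc1)[C@H]2CCc1cccc(C(F)(F)F)c1` gives 10 nM in a functional assay on CHO cells for antagonist activity at Orexin receptor type 2 (Homo sapiens), read by FLIPR and calcium flux (a lower number here means a stronger inhibitor, a higher number a weaker inhibitor), compound 2 `CCc1nc(Cl)c2n1CCN([C@@H](C(=O)NC)c1ccccc1)[C@H]2COc1ccc(C(F)(F)F)cc1` gives 9 nM in this assay, and compound 3 `CCc1nc(Cl)c2n1CCN([C@@H](C(=O)NC)c1ccccc1)[C@H]2CCc1ccc(C(F)(F)F)c(Cl)c1` gives 18 nM in this assay. Compound 3 has the highest of the three numbers, yet a 1.8-fold higher number from compound 1 to compound 3 (0.26 log units; within the scatter) and a 2.0-fold higher number from compound 2 to compound 3 (0.30 log units; within the scatter) both stay within the scatter, as does a 1.1-fold lower number from compound 1 to compound 2 (0.05 log units; within the scatter). Compound 4 `CCc1nc(Cl)c2n1CCN([C@@H](C(=O)NC)c1ccccc1)[C@H]2CCc1ccc(C(F)(F)F)cc1F` differs from compound 3 by 2-fluoro-4-(trifluoromethyl)phenyl in place of 3-chloro-4-(trifluoromethyl)phenyl on a saturated chain carbon, two bonds along the chain from a saturated ring carbon. Going by the values given here, the one measured step that bears on this, a change of substitution on the same aromatic ring, is a 1.8-fold higher number from compound 1 to compound 3 (0.26 log units; within the scatter), and it stayed within the scatter. No step beyond the scatter is therefore expected for compound 4 in this assay. The estimated step is a 1.3-fold lower number from compound 3 to compound 4 (0.11 log units; within the scatter). Compound 4 is expected to give 14 nM, with a range of 5 nM to 40 nM.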

Compound 4, half-maximal inhibitory concentration: 12 nM
Estimate against measurement, compound 4: 1.2-fold (0.07 log units) above; low and high end bracket the measured number.
By their numbers in this assay, from the lowest: compounds 2, 1, 4 and 3 (each within the scatter of the next).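

In this assay the 2-fluoro-4-(trifluoromethyl)phenyl group replaces 3-chloro-4-(trifluoromethyl)phenyl with a 1.5-fold lower number from compound 3 to compound 4 (0.18 log units; within the scatter) and so stays level with it at this chain position. Set against the other two groups, a 1.2-fold higher number from compound 1 to compound 4 (0.08 log units; within the scatter) and a 1.3-fold higher number from compound 2 to compound 4 (0.12 log units; within the scatter) are likewise small, so all four compounds shown remain within the scatter of one another on this side chain. No measurement on hand explains this flat picture. Still open, going by these compounds, is whether a carboxylic acid or an amine on this aromatic ring would give a step beyond the scatter. On these data alone, a longer chain between the ring and the core is equally open.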